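Phenyl for 4-fluorobenzyl on the shared core of compound 1

The source may hold more compounds than are shown below. What is called first, only, known or untested is meant among the compounds shown, and "the series" means these compounds.

Measured so far in a functional assay on cells (Platelet, Homo sapiens) for inhibition; a higher number here means a weaker inhibitor, a lower number a stronger inhibitor:
- compound 1 `CCOC(=O)c1ccc(-c2nn(Cc3ccc(F)cc3)c3ccccc23)cc1`: > 10000 nM, a limit of the assay
- compound 2 `CCCNC(=O)c1ccc(-c2nn(Cc3ccccc3)c3ccccc23)cc1`: > 10000 nM, a limit of the assay
- compound 3 `CCOC(=O)/C=C/c1ccc(-c2nn(Cc3ccccc3)c3ccccc23)cc1`: > 10000 nM, a limit of the assay

In this assay compound 1 stands only at a limit; (the limit of > 10000 nM in this assay, at which 3 of the 3 values shown sit). Among the compounds with values here, the one step between measured compounds, a step that the two limits leave unreadable from compound 2 to compound 3, concerns the ester-bearing side and is unreadable, so no measured step bears on the change to compound 4 `CCOC(=O)c1ccc(-c2nn(-c3ccccc3)c3ccccc23)cc1`, which is phenyl in place of 4-fluorobenzyl on an aromatic nitrogen. With every value at the limit, compound 4 is expected to remain weak, most likely at the limit again, and the step that the limit leaves unreadable from compound 1 to compound 4 is expected to be unreadable. The estimate for compound 4 is 15000 nM, with a range from 4000 nM to 50000 nM.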

Compound 4, half-maximal inhibitory concentration: > 10000 nM
Compound 4: no number, only a limit; the forecaster's own chance of this, stated with the estimate: 75%; the middle value does not contradict the limit.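

In this assay, compound 1 and compound 4 both stand only at a limit of the assay, so the change between them cannot be read: the limit of > 10000 nM in this assay, at which 4 of the 4 values shown sit.

The compounds shown leave open whether any group on the shared core gives a measurable value, and what phenyl in place of 4-fluorobenzyl does.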